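Naphthyloxyacetohydrazone series: cytotoxicity on HEL cells

The source may hold more compounds than are shown below. What is called first, only, known or untested is meant among the compounds shown, and "the series" means these compounds.

Three hydrazones of the shared core have been measured in an ADME assay on HEL cells (Homo sapiens) for cytotoxicity; a higher number here means that more compound is tolerated, a lower number that less compound is tolerated. Compound 1 `CCOc1ccc(/C=N/NC(=O)COc2cccc3ccccc23)cc1O` gives 18.1 ug/mL, and compound 2 `C/C(=N\NC(=O)COc1cccc2ccccc12)c1ccccc1` gives 20 ug/mL. Compound 3 `O=C(COc1cccc2ccccc12)N/N=C/C=C/c1ccccc1` gives 100 ug/mL, the highest of the three numbers, beyond the scatter from both compound 2 and compound 1. Compound 4 `O=C(COc1cccc2ccccc12)N/N=C/c1cccc(Br)c1` differs from compound 3 only by 3-bromophenyl in place of 2-phenylethenyl on a carbon with a double bond to nitrogen. For the measured compounds named here, no measured pair shows this change. The two aryl hydrazones compound 1 and compound 2 sit well below compound 3, so a drop beyond the scatter in this assay is expected for compound 4, on the order of a 4.0-fold lower number from compound 3 to compound 4 (0.60 log units; beyond the scatter). Compound 4 is expected to give 25 ug/mL, with a range of 10 ug/mL to 60 ug/mL.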

Compound 4, half-maximal cytotoxic concentration: 48.6 ug/mL
Estimate against measurement, compound 4: 1.9-fold (0.29 log units) below; the measured number falls inside the stated range.
By their numbers in this assay, from the lowest: compounds 1 and 2 (each within the scatter of the next); then compound 4; then compound 3.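

At the carbon with a double bond to nitrogen, 3-bromophenyl in place of 2-phenylethenyl gives the series its first comparison in one place: in this assay the change brings a 2.1-fold lower number from compound 3 to compound 4 (0.31 log units; beyond the scatter), a modest step. The number at this position therefore moves with the group it carries, even with one six-membered aromatic ring kept on both sides of the change. No measured evidence accounts for the step.

Open, as far as these compounds go, is whether the step belongs to the bromine or to the loss of the double bond outside the aromatic ring, which a plain phenyl on this carbon would separate. From the compounds shown here alone, how an amine or a carboxylic acid on that ring would read in this assay also remains open.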